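Methylpiperazine chain variants on the indole nitrogen

This account rests on a few compounds, and the source may have more. Where it says the series, first, only, none or still open, it means among the compounds named here.

Measured so far:
- compound 1 `O=C1c2c[n+]([O-])c3ccccc3c2C(=O)c2c1c1ccccc1n2Cc1cn(C[C@H](O)CO)nn1`: 350 nM
- compound 2 `CN1CCN(CCCn2c3c(c4ccccc42)C(=O)c2c[n+]([O-])c4ccccc4c2C3=O)CC1`: 470 nM
- compound 3 `O=C1c2c[n+]([O-])c3ccccc3c2C(=O)c2c1c1ccccc1n2Cc1cn(C[C@@H](O)CO)nn1`: 140 nM

In a functional assay on A-375 cells (Homo sapiens) for cytotoxicity, read by MTT assay, with a stated time of 72 h (on this read-out lower numbers stand for stronger inhibition and higher numbers for weaker inhibition), compound 1 gives 350 nM, the second highest of the three numbers. Its nearest neighbour is compound 2 with 470 nM, and a 1.3-fold higher number from compound 1 to compound 2 (0.13 log units; within the scatter). Compound 3 gives 140 nM; a 2.5-fold lower number from compound 1 to compound 3 (0.40 log units; beyond the scatter), and this pair is informative because of the fact that compounds 1 and 3 differ only in the configuration as drawn. Between the other two, a 3.4-fold lower number from compound 2 to compound 3 (0.53 log units; beyond the scatter).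

Compound 4 `CN1CCN(CCCCCn2c3c(c4ccccc42)C(=O)c2c[n+]([O-])c4ccccc4c2C3=O)CC1` is unmeasured. Relative to compound 1 the change is 4-(4-methylpiperazin-1-yl)butyl in place of 1-(2,3-dihydroxypropyl)-1H-1,2,3-triazol-4-yl on a saturated chain carbon bound to an aromatic nitrogen. Among the measured compounds shown here, the only measured step that bears on it is the one from compound 1 to compound 2, which swapped the same triazole group for a 2-(4-methylpiperazin-1-yl)ethyl chain and stayed within the scatter. For the measured compounds named here, compound 4 carries the methylpiperazine on a longer chain, 5-(4-methylpiperazin-1-yl)pentyl by the outer cut, and no measured compound tests that length. A step near that of compound 2, i.e. none beyond the scatter, is the expectation.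

For compound 4 in this assay the estimate is 450 nM, range 180 nM to 1100 nM. This estimate means a 1.3-fold higher number from compound 1 to compound 4 (0.11 log units; within the scatter), expected to fall within the usual scatter.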

Compound 4, half-maximal inhibitory concentration: 1710 nM
Compound 4: middle estimate off by 3.8-fold (0.58 log units), on the low side; the measured number lies above the stated range.
By their numbers in this assay, from the lowest: compound 3; then compounds 1 and 2 (each within the scatter of the next); then compound 4.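

In this assay the length of the chain on the aromatic nitrogen matters: the longer 5-(4-methylpiperazin-1-yl)pentyl chain gives a 3.6-fold higher number from compound 2 to compound 4 (0.56 log units; beyond the scatter) with the methylpiperazine kept. Against the triazole compounds this chain also carries a cost, with a 4.9-fold higher number from compound 1 to compound 4 (0.69 log units; beyond the scatter) and a 12-fold higher number from compound 3 to compound 4 (1.09 log units; beyond the scatter) as the two readings, the second being the larger. The match between compound 2 and compound 1 therefore holds for the shorter chain of compound 2 only and does not extend to the methylpiperazine group as such.

Still open, on these data alone, is how a chain of intermediate length behaves, and whether another amine such as morpholine on the same chains follows the methylpiperazine. The configuration contrast between compound 1 and compound 3 concerns the diol and not this chain, so nothing shown accounts for the rise on chain lengthening.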